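The source may report more compounds than this note shows. Statements on the series, on what has been measured and on what is new or still open speak of the compounds shown alone.

Measured so far:
compound 1 `O=C(/C=C/c1ccc2c(c1)B(O)OC2)c1cccs1` gives 10400 nM
compound 2 `O=C(/C=C/c1ccc2c(c1)B(O)OC2)c1ccc(I)cc1` gives 4200 nM
compound 3 `O=C(/C=C/c1ccc2c(c1)B(O)OC2)c1cccc(O)c1` gives 3800 nM

In a functional assay on SK-OV-3 cells (Homo sapiens) for cytotoxicity, read by MTT assay, with a stated time of 48 h (a higher number here means a weaker inhibitor, a lower number a stronger inhibitor), compound 3 has the lowest of the three numbers. The step of a 2.7-fold lower number from compound 1 to compound 3 (0.44 log units; beyond the scatter) lies beyond the scatter, but the step of a 1.1-fold lower number from compound 2 to compound 3 (0.04 log units; within the scatter) lies within it, so compound 2 and compound 3 cannot be told apart on these numbers.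

Compound 4 `Nc1cccc(C(=O)/C=C/c2ccc3c(c2)B(O)OC3)c1` differs from compound 3 by one change: amino in place of hydroxy on an aromatic carbon. Among the compounds with values here, no measured step swaps an amino for a hydroxy. The nearest comparison, a 1.1-fold lower number from compound 2 to compound 3 (0.04 log units; within the scatter), exchanged one substituent on the phenyl ring for another without a step beyond the scatter. The expected step is therefore small, no change at the digits printed from compound 3 to compound 4 (within the scatter), in no clear direction. For compound 4 the estimate in this assay is 3800 nM, expected between 1500 nM and 9500 nM.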

Compound 4, half-maximal inhibitory concentration: 7400 nM
Compound 4: the middle estimate sits 1.9-fold (0.29 log units) below what was measured; the measured number falls inside the stated range.
By their numbers in this assay, from the lowest: compounds 3, 2, 4 and 1 (each within the scatter of the next, the first and the last beyond it).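

Swapping hydroxy for amino on the phenyl ring gives a 1.9-fold higher number from compound 3 to compound 4 (0.29 log units; within the scatter) in this assay, so the two groups cannot be told apart at this position. The 3-aminophenyl compound also stays level with the 4-iodophenyl one, at a 1.8-fold higher number from compound 2 to compound 4 (0.25 log units; within the scatter), and, unlike the 3-hydroxyphenyl compound, it does not separate from the thiophen-2-yl one, at a 1.4-fold lower number from compound 1 to compound 4 (0.15 log units; within the scatter). No measurement here accounts for these numbers. From the compounds shown here alone, whether a carboxylic acid or a methoxy group at this position would move the number beyond the scatter stays open, and so does the effect of moving the amino group elsewhere on the ring.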